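The source may hold more compounds than are shown below. What is called first, only, known or untested is meant among the compounds shown, and "the series" means these compounds.

Compound 1 `CCCn1c(SCc2cc([N+](=O)[O-])ccc2OC)nc2cc(NC(=O)NC(C)(C)C)ccc21` is the starting point. In an assay on isolated protein for inhibition of Gonadotropin-releasing hormone receptor (Rattus norvegicus) (on this read-out lower numbers stand for stronger inhibition and higher numbers for weaker inhibition), compound 1 gives 120 nM, the second highest of the three numbers at hand. Its nearest neighbour is compound 3 `COc1ccc([N+](=O)[O-])cc1CSc1nc2cc(NC(=O)NC(C)(C)C)ccc2n1C(C)C`, which in this assay gives 62 nM; the furthest is compound 2 `COCCn1c(SCc2cc([N+](=O)[O-])ccc2OC)nc2cc(NC(=O)NC(C)(C)C)ccc21`, which in this assay gives 280 nM. The measured steps all concern the group on the aromatic nitrogen of the shared core: a 2.3-fold higher number from compound 1 to compound 2 (0.37 log units; beyond the scatter), a 1.9-fold lower number from compound 1 to compound 3 (0.29 log units; within the scatter) and a 4.5-fold lower number from compound 2 to compound 3 (0.65 log units; beyond the scatter).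

Compound 4 `CCCn1c(SCc2cc([N+](=O)[O-])ccc2OC)nc2cc(NC(=O)NC(C)(C)C)cc(C(=O)N(C)C)c21` differs from compound 1 elsewhere: dimethylcarbamoyl in place of hydrogen on an aromatic carbon. Going by the values given here, none of the three measured steps touches an aromatic carbon of the core, so no step bears directly on this change. What the measured compounds do show is that the numbers stay close to one another across the whole set, with the widest spread being the modest step from compound 2 to compound 3. With nothing to point in either direction, compound 4 is expected to give a number in this assay near that of compound 1, the expected step being a 1.3-fold higher number from compound 1 to compound 4 (0.10 log units; within the scatter). The estimate for compound 4 in this assay is therefore 150 nM, with a range from 45 nM to 500 nM.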

Compound 4, half-maximal inhibitory concentration: 200 nM
Estimate against measurement, compound 4: 1.3-fold (0.12 log units) below; low and high end bracket the measured number.
By their numbers in this assay, from the lowest: compounds 3, 1, 4 and 2 (each within the scatter of the next, the first and the last beyond it).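

Dimethylcarbamoyl, with its 5 heavy atoms, on the aromatic carbon ortho to a fused ring and meta to a ((tert-butyl)carbamoyl)amino group gives the first reading from a carbon of the core rather than from its aromatic nitrogen. In this assay the result is a 1.7-fold higher number from compound 1 to compound 4 (0.22 log units; within the scatter), so this single change leaves compound 4 not separable from compound 1, and at this position a group of this size can replace hydrogen without a shift that stands clear of repeat measurement. The compounds shown offer no measurement that speaks to why the number sits where it does.

As far as these compounds go, this is one group at one position, so it remains open whether a carboxylic acid, an amine or a simple methyl on the same aromatic carbon would give a number beyond the scatter from compound 1. From the compounds shown here alone, it is also open whether dimethylcarbamoyl at this carbon would give a similar step when paired with the isopropyl of compound 3 or the 2-methoxyethyl of compound 2 on the aromatic nitrogen.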